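This account rests on a few compounds, and the source may have more. Where it says the series, first, only, none or still open, it means among the compounds named here.

Measured compounds:
- compound 1, `COc1cc2c(Oc3ccc(NC(=O)N/N=C/c4ccc(Cl)cc4Cl)cc3F)ccnc2cc1OCCCN1CCCCC1` — "not determined" (no result reported)
- compound 2, `COc1cc2c(Oc3ccc(NC(=O)N/N=C/c4ccc(OC(F)(F)F)cc4)cc3F)ccnc2cc1OCCCN1CCCCC1` — 590 nM
- compound 3, `COc1cc2c(Oc3ccc(NC(=O)N/N=C/c4ccc(N(C)C)cc4)cc3F)ccnc2cc1OCCCN1CCCCC1` — "not determined" (no result reported)

The three measured compounds share one core and differ only in the aryl group attached to the carbon with a double bond to nitrogen. In a functional assay on A549 cells (Homo sapiens) for cytotoxicity, read by MTT assay, with a stated time of 72 h (on this read-out lower numbers stand for stronger inhibition and higher numbers for weaker inhibition), compound 2 gives 590 nM. For compound 1 the entry in this assay reads "not determined" (no result reported). For compound 3 the entry in this assay reads "not determined" (no result reported), so compound 3 stands without a single number; it is one of two entries here that carry no value.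

Compound 4, `C=CCc1cccc(/C=N/NC(=O)Nc2ccc(Oc3ccnc4cc(OCCCN5CCCCC5)c(OC)cc34)c(F)c2)c1OC`, differs from compound 3 by 3-allyl-2-methoxyphenyl in place of 4-(dimethylamino)phenyl on a carbon with a double bond to nitrogen. Within the data shown here, no step between measured compounds is known, and compound 3 itself has no number, so the step from compound 3 to compound 4 cannot be sized from data; the only anchor is compound 2. The expectation is therefore that compound 4 lands near the range of compound 2, without a direction beyond the scatter being claimed. Compound 4 is estimated at 800 nM, with a range from 200 nM to 3500 nM.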

Compound 4, half-maximal inhibitory concentration: 250 nM
Estimate against measurement, compound 4: 3.2-fold (0.51 log units) above; measured number inside the range.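

In this assay the aryl group on the carbon with a double bond to nitrogen now has its first readable step: 3-allyl-2-methoxyphenyl in place of 4-(trifluoromethoxy)phenyl gives a 2.4-fold lower number from compound 2 to compound 4 (0.37 log units; beyond the scatter), a modest change but one beyond the usual scatter, so the read-out does respond to the aryl group at this position. Any step involving compound 1 or compound 3 cannot be read, and the effect of leaving 4-(dimethylamino)phenyl therefore remains unsized. No measurement available here accounts for the step.

The compounds shown leave open whether the allyl group, the methoxy group or the two together go with the lower number. They also leave open how a propyl chain in place of the allyl group, or a carboxylic acid on the aryl ring, would read.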